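Series notes: a heteroaromatic ring in place of the carbon ring

A few compounds are considered here, and "the series" means these few. Any claim that something is new, unique, unknown or untested is made for them only; others in the source may bear on it.

In an assay on HeLa cells for inhibition of Kinesin-like protein KIF15 (Homo sapiens), read by microscopy, with stated times of 2 s and 20 s, tested at 750 nM (a lower number here means less inhibition, a higher number more inhibition at the concentration tested (going by the name of the read-out)), compound 1 `O=C1Nc2ccc(C(=O)c3ccco3)cc2/C1=C/c1cc(Cl)c(O)c(Br)c1` gives 62% and stands highest of the two measured numbers. Its nearest neighbour, compound 2 `COc1c(Br)cc(/C=C2\C(=O)Nc3ccc(C(=O)c4ccco4)cc32)cc1Br`, gives -12.6% in this assay, a gap that lies beyond the usual scatter. Within the data shown here, no pair of measured compounds differs in only one place, so the size of a single change in this assay is not yet known from the data at hand.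

Compound 3 `O=C1Nc2ccc(C(=O)c3ccco3)cc2/C1=C/c1ccc(O)nc1` is the next step from compound 1. The change: a group of 7 heavy atoms (5 carbon, 1 nitrogen, 1 oxygen; one six-membered aromatic ring with 1 hetero atom) in place of a group of 9 heavy atoms (6 carbon, 1 oxygen, 1 chlorine, 1 bromine; one six-membered aromatic ring of carbon only), on a double-bonded chain carbon bound to a double-bonded ring carbon. The six-membered aromatic ring of carbon only, with its chlorine and bromine, leaves, and a 6-hydroxypyridin-3-yl enters.

The step is expected to be a fall beyond the scatter, a number 37 percentage points lower from compound 1 to compound 3 (beyond the scatter). Compound 3 is estimated at 25% in this assay, with a range from -10% to 55%.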

Compound 3, a percentage reported as inhibition, at one concentration (the size of the read-out at that concentration, not a potency): 26.5%
Estimate against measurement, compound 3: 1.5 percentage points below; low and high end bracket the measured number.
By their numbers in this assay, from the lowest: compound 2; then compound 3; then compound 1.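

Among these compounds, at the double-bonded chain carbon bound to a double-bonded ring carbon, exchanging the chlorine- and bromine-bearing carbon ring for 6-hydroxypyridin-3-yl gives, in this assay, a number 35.5 percentage points lower from compound 1 to compound 3 (beyond the scatter) and thus the first single-place step, a large one. With this group, compound 3 still gives 26.5% in this assay, so the shared core keeps a positive read-out without either halogen. No measurement on hand bears on the origin of this step.

On these data alone, the step changes the ring and removes both halogens at once, so the share of each change remains open. A hydroxyphenyl ring carrying neither chlorine nor bromine would separate them, and an amino group in place of the hydroxyl on the 6-hydroxypyridin-3-yl would test that substituent.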